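Removing a methyl from the core of compound 1

This account rests on a few compounds, and the source may have more. Where it says the series, first, only, none or still open, it means among the compounds named here.

Among the compounds with values here, in a functional assay (Mus musculus) for inhibition, read by cell counting, with a stated time of 3 days (on this read-out higher numbers stand for weaker inhibition and lower numbers for stronger inhibition), compound 1 `COc1ccc(N(C)c2nc(C)nc3c2nc(C)n3C)cc1` gives 8700 nM, the only number so far. Compound 2 `COc1ccc(N(C)c2ncnc3c2nc(C)n3C)cc1` reaches only a limit, >= 100000 nM. Compound 3 `COc1ccc(N(C)c2nc(C)nc3c2ncn3C)cc1` carries the change (hydrogen in place of methyl on an aromatic carbon), on an aromatic carbon between two ring nitrogen atoms. Within the data shown here, one measured step bears on it: an at least 11-fold higher number from compound 1 to compound 2 (1.06 log units; beyond the scatter), the same exchange of methyl for hydrogen at a different carbon, and large. On the precedent of compound 2, a move to a higher number in this assay is expected, its size uncertain. The expected step is a 3.4-fold higher number from compound 1 to compound 3 (0.54 log units; beyond the scatter). For compound 3 the estimate is 30000 nM, with an expected range of 8000 nM to 100000 nM.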

Compound 3, half-maximal inhibitory concentration: 15000 nM
The estimate for compound 3 lay 2.0-fold (0.30 log units) above the measured number; the range from low to high includes it.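

On the aromatic carbon between two ring nitrogen atoms, hydrogen in place of methyl gives only a small shift in this assay, which stays within the scatter: a 1.7-fold higher number from compound 1 to compound 3 (0.24 log units; within the scatter). The methyl group at this carbon is therefore not needed for the inhibition seen with compound 1. The exchange at the other carbon gives a different picture, and compound 2 gives a limit rather than a number: the limit of >= 100000 nM in this assay, at which 1 of the 3 values shown sits.

On these data alone, whether a larger group here, such as an ethyl chain or an amine, would shift the number remains open. So does the outcome of a carboxylic acid at this carbon.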